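Saturating the Side-Chain Double Bond in a Vitamin D Receptor Ligand

The source may report more compounds than this note shows. Statements on the series, on what has been measured and on what is new or still open speak of the compounds shown alone.

Three compounds share one core and differ only in the group on the aromatic ring. Compound 1 `C#Cc1ccc(C(CC)(CC)C2=CN(CC)C(C(=O)NCCN(CC)CC)C2)cc1C` was tested in an assay on isolated protein for binding affinity to vitamin D3 receptor (Homo sapiens), read by fluorescence polarization, tested at 1 uM (a lower number here means less inhibition, a higher number more inhibition at the concentration tested (going by the name of the read-out)), and is reported for compound 1 as "not active" (no number reported), with no number given. Among the measured compounds shown here, compound 2 `CCN(CC)CCNC(=O)C1CC(C(CC)(CC)c2ccc(/C=C/C(O)(CC)CC)c(C)c2)=CN1CC` gives 65.5% in this assay; this is the only number recorded so far, so compound 2 is the one fixed point, and compound 1 offers no value to compare it with.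

Compound 3 `CCN(CC)CCNC(=O)C1CC(C(CC)(CC)c2ccc(CCC(O)(CC)CC)c(C)c2)=CN1CC` has not been measured. Its difference from compound 2 is a group of 8 heavy atoms (7 carbon, 1 oxygen; no ring) in place of a group of 8 heavy atoms (7 carbon, 1 oxygen; no ring), on an aromatic carbon. The group that leaves carries 1 double bond outside aromatic rings; the 3-ethyl-3-hydroxypentyl group that enters does not, and everything else stays as it is.

For the measured compounds named here, no step between two measured compounds is available to calibrate this change. The expectation is therefore a modest shift, with the step of a number 8.5 percentage points lower from compound 2 to compound 3 (within the scatter) estimated to lie within the scatter or only slightly below it. For compound 3 the expected inhibition in this assay is 57%, within a range from 35% to 75%.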

Compound 3, a percentage reported as inhibition, at one concentration (the size of the read-out at that concentration, not a potency): 35.9%
Beside the measured number, compound 3's estimate is 21.1 percentage points above it, within the range that was stated.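

In this assay, the double bond in the side chain proves to matter at this position on the aromatic ring: saturating it gives a number 29.6 percentage points lower from compound 2 to compound 3 (beyond the scatter), even though the group that leaves and the 3-ethyl-3-hydroxypentyl group that enters have the same heavy-atom count and the same hydrogen-bond donor and acceptor counts. The double bond is not essential for a numerical reading, however: compound 3 still gives 35.9%, while compound 1 is recorded as "not active" (no number reported). Nothing measured here explains why this single change lowers the reading.

The compounds shown leave open how the side chain would behave with a carbon-carbon triple bond in place of the double bond, with a longer chain carrying the same hydroxyl, or with an amine in place of that hydroxyl. Going by these compounds, each reading also comes from a single concentration, and how this step would translate into a true measure of potency remains unknown.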